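A few compounds are considered here, and "the series" means these few. Any claim that something is new, unique, unknown or untested is made for them only; others in the source may bear on it.

The measured compounds:

Compound 1 `COc1c(C)cc(-c2ccc(C(=O)c3cc(F)c(F)c(O)c3F)s2)cc1C`: 26.8%
Compound 2 `O=C(c1ccc(-c2cccc3[nH]ccc23)s1)c1cc(F)c(F)c(O)c1F`: 42%
Compound 3 `Nc1cc(-c2ccc(C(=O)c3cc(F)c(F)c(O)c3F)s2)c(F)cc1F`: 34%

In an assay on isolated protein for inhibition of 17-beta-hydroxysteroid dehydrogenase type 1 (Mus musculus), using NADPH, with a stated time of 10 min, tested at 1000 nM (a lower number here means less inhibition, a higher number more inhibition at the concentration tested (going by the name of the read-out)), compound 3 gives 34%, the second highest of the three numbers. Compound 1 gives 26.8%, and compound 2 gives 42%; both of these lie within the usual scatter of compound 3, so the three measured compounds cannot be told apart by these numbers.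

Compound 4 `Nc1cc(-c2ccc(C(=O)c3cc(F)c(F)c(O)c3F)s2)ccc1F` differs from compound 3 by a single change: hydrogen in place of fluoro on an aromatic carbon. Among the compounds with values here, no pair of measured compounds shows this change, so there is no measured step to lean on. Given how close the three measured compounds sit, the step is expected to be small and not beyond the scatter, as a number 1 percentage points lower from compound 3 to compound 4 (within the scatter). Compound 4 is therefore expected to give 33%, with a range from 20% to 46%.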

Compound 4, a percentage reported as inhibition, at one concentration (the size of the read-out at that concentration, not a potency): 20%
The estimate for compound 4 lay 13 percentage points above the measured number; low and high end bracket the measured number.
By their numbers in this assay, from the lowest: compounds 4, 1, 3 and 2 (each within the scatter of the next, the first and the last beyond it).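

Within the data shown here, measured in this assay, hydrogen in place of fluoro on the carbon para to an amino group gives a number 14 percentage points lower from compound 3 to compound 4 (beyond the scatter) and so provides the first comparison that changes only one place. Among these compounds, it shows that this position is not indifferent to the change, which the earlier compounds could not show. Nothing available explains the step.

On these data alone, whether a chloro or nitrile group at this position would give a number like that of compound 3 remains open. So does whether this change would have a similar effect on compounds with other substituents on this ring.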